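Swapping Benzylamino for Azetidinyl on a Shared Core

The source may report more compounds than this note shows. Statements on the series, on what has been measured and on what is new or still open speak of the compounds shown alone.

Compound 1 `Cc1ccc(NC2=CC(=O)c3c(nc4n3[C@H]3OC[C@@H](O)[C@H]3OC4)C2=O)cc1C` gives 4090 nM in a functional assay on ECa-109 cells for inhibition, with ECa-109 cell line (Homo sapiens) as the target, read by sulforhodamine B assay; a higher number here means a weaker inhibitor, a lower number a stronger inhibitor. Compound 2 `O=C1C(NC2CCCC2)=CC(=O)c2c1nc1n2[C@H]2OC[C@@H](O)[C@H]2OC1` reaches only the limit of > 16000 nM in this assay. Compound 3 `O=C1C(NCc2ccccc2)=CC(=O)c2c1nc1n2[C@H]2OC[C@@H](O)[C@H]2OC1` likewise reaches only the limit of > 8000 nM in this assay, so where it stands is known only as a floor. The step of an at least 1.9-fold higher number from compound 1 to compound 3 (0.29 log units; that floor lies within the scatter) cannot be separated from scatter, and the step that the two limits leave unreadable from compound 2 to compound 3 is unreadable. Compound 4 `O=C1C(N2CCC2)=CC(=O)c2c1nc1n2[C@H]2OC[C@@H](O)[C@H]2OC1` differs from compound 3 by azetidin-1-yl in place of benzylamino on a double-bonded ring carbon. Going by the values given here, the one measured step that bears on this kind of amine swap is weak evidence, and compound 2, carrying cyclopentyl on the amine nitrogen, sits at the limit of > 16000 nM in this assay, at which 1 of the 3 values shown sits. Compound 4 is therefore expected to stay weak, with a step that the limit leaves unreadable from compound 3 to compound 4 estimated as no clear change, most likely another limit. Compound 4 is expected to give about 12000 nM, between 4000 nM and 40000 nM.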

Compound 4, half-maximal inhibitory concentration: > 16000 nM
Compound 4: no number, only a limit; the forecaster's own chance of this, stated with the estimate: 70%; middle value at least 1.3-fold (0.12 log units) from the limit.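

Azetidin-1-yl, with 0 hydrogen-bond donors where benzylamino has 1, brings an at least 3.9-fold higher number from compound 1 to compound 4 (0.59 log units; beyond the scatter), so this small ring on the double-bonded ring carbon does not match the (3,4-dimethylphenyl)amino of compound 1. Compound 4 shares its limit with compound 2: the limit of > 16000 nM in this assay, at which 2 of the 4 values shown sit. Compounds 2, 3 and 4 all stand as limits, and the steps among them cannot be read.

Going by these compounds, their true order remains open. So does whether another group in this place, such as 4-chlorophenylamino or morpholin-4-yl, would improve on compound 1.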